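Sulfonamide series: alkoxy extension on the fused core

The source may report more compounds than this note shows. Statements on the series, on what has been measured and on what is new or still open speak of the compounds shown alone.

In a functional assay on cells for antagonist activity at C-C chemokine receptor type 4 (Homo sapiens), read by GTPgammaS binding (on this read-out higher numbers stand for weaker inhibition and lower numbers for stronger inhibition), compound 3 `Cn1ncc2c(NS(=O)(=O)c3cccc(Cl)c3Cl)ncnc21` gives 1260 nM, the lowest of the three numbers in hand. Compound 1 `Cn1ncc2c(NS(=O)(=O)c3cccc(Cl)c3Cl)cccc21` gives 3160 nM and compound 2 `Cn1ncc2c(NS(=O)(=O)c3cccc(Cl)c3Cl)ccnc21` gives 12600 nM in this assay; both gaps from compound 3 lie beyond the scatter. For the measured compounds named here, no single-change comparison between measured compounds exists, so the next step has no precedent within the set. Compound 4 `COCCOc1nn(C)c2ncnc(NS(=O)(=O)c3cccc(Cl)c3Cl)c12` differs from compound 3 by 2-methoxyethoxy in place of hydrogen on an aromatic carbon. Going by the values given here, with no measured step to lean on, the expectation is a small change, slightly toward a lower number or none beyond the scatter, estimated as a 1.6-fold lower number from compound 3 to compound 4 (0.20 log units; within the scatter). Compound 4 is therefore expected at 800 nM, within a range from 200 nM to 3000 nM.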

Compound 4, half-maximal inhibitory concentration: 794 nM
Beside the measured number, compound 4's estimate is 1.0-fold (0.00 log units) above it; the measured number falls inside the stated range.
By their numbers in this assay, from the lowest: compounds 4 and 3 (each within the scatter of the next); then compound 1; then compound 2.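

For the compounds shown here, this is the first single-change comparison: with 2-methoxyethoxy in place of hydrogen on an aromatic carbon of the five-membered ring, the result is a 1.6-fold lower number from compound 3 to compound 4 (0.20 log units; within the scatter). This position therefore accepts a chain of 5 heavy atoms with no change beyond the scatter. No supporting data bear on the reason for this result. From the compounds shown here alone, whether a longer chain or one ending in a dimethylamino group would shift the number beyond the scatter remains open. Also open, going by these compounds, is how a methoxy group at this carbon would read.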